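Two Methyl Groups Fewer on the Amide Aryl Ring

The compounds below may be only part of what the source reports. "The series", "measured", "known", "first", "only" and "open" are said of these compounds alone.

Among the measured compounds shown here, compound 1 `Cc1cccc(C)c1NC(=O)/C=C/C(=O)N1C/C(=C\c2ccccc2)C(=O)/C(=C/c2ccccc2)C1` gives 6600 nM in a functional assay on Molt4/C8 cells (Homo sapiens) for cytotoxicity (a higher number here means a weaker inhibitor, a lower number a stronger inhibitor), the higher of the two numbers measured so far. Compound 2 `Cc1ccc(NC(=O)/C=C/C(=O)N2C/C(=C\c3ccc([N+](=O)[O-])cc3)C(=O)/C(=C/c3ccc([N+](=O)[O-])cc3)C2)cc1C` gives 660 nM in this assay, but it differs from compound 1 in more than one place, so the two values show only a gap, not a single step. Compound 3 `O=C(/C=C/C(=O)N1C/C(=C\c2ccccc2)C(=O)/C(=C/c2ccccc2)C1)Nc1ccccc1` is compound 1 with phenyl in place of 2,6-dimethylphenyl on an amide-type nitrogen. For the measured compounds named here, no measured pair isolates this change, so the expected step is a 1.2-fold lower number from compound 1 to compound 3 (0.08 log units; within the scatter), not beyond the scatter in either direction. Compound 3 is therefore estimated at 5500 nM, within 2000 nM to 15000 nM.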

Compound 3, half-maximal inhibitory concentration: 520 nM
For compound 3 the middle estimate is 11-fold (1.02 log units) above the measured one; the whole stated range lies above it.
By their numbers in this assay, from the lowest: compounds 3 and 2 (each within the scatter of the next); then compound 1.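

In this assay the change to phenyl in place of 2,6-dimethylphenyl on an amide-type nitrogen gives a 13-fold lower number from compound 1 to compound 3 (1.10 log units; beyond the scatter) with the rest of the molecule untouched. This single change alone moves the number well beyond the scatter, something the gap between compound 1 and compound 2 could not show. No available measurement explains why the step is so large. Still open, going by these compounds, is whether removing one methyl group would give the same step, and how a methoxy group or a chlorine atom on the phenyl of compound 3 would read.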